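A Methyl Group on a Shared Core, Measured Twice

This account rests on a few compounds, and the source may have more. Where it says the series, first, only, none or still open, it means among the compounds named here.

Of the compounds shown here, three have so far been measured in a functional assay on HeLa cells (Homo sapiens) for antiproliferative activity, read by MTT assay, with a stated time of 48 h; a lower number here means a stronger inhibitor, a higher number a weaker inhibitor. Compound 2 `CS(=O)(=O)c1ccc(Nc2nccc(Nc3nc4ccc(Cl)cc4s3)n2)cc1` gives 1400 nM, and compound 1 `Cc1cnc(Nc2ccc(S(C)(=O)=O)cc2)nc1Nc1nc2ccc(Cl)cc2s1` gives 4180 nM. The two differ in one place: methyl in place of hydrogen on an aromatic carbon. That change made a 3.0-fold higher number from compound 2 to compound 1 (0.48 log units; beyond the scatter), so the number rose and the inhibition weakened. Compound 3 `NS(=O)(=O)c1ccc(Nc2nccc(Nc3nc4ccc(F)cc4s3)n2)cc1` gives 450 nM in this assay, the lowest of the three numbers; the difference between its core and the core of compound 2 is not broken down here.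

Compound 4 `Cc1cnc(Nc2ccc(S(N)(=O)=O)cc2)nc1Nc1nc2ccc(F)cc2s1` has not yet been measured in this assay. It differs from compound 3 in one place: methyl in place of hydrogen on an aromatic carbon. Among the measured compounds shown here, this is the same change as the one from compound 2 to compound 1, made at the same place. For the measured compounds named here, on that basis the step is expected to be a 2.9-fold higher number from compound 3 to compound 4 (0.46 log units; beyond the scatter), a weakening rather than a gain, resting on the single earlier step of a 3.0-fold higher number from compound 2 to compound 1 (0.48 log units; beyond the scatter). Compound 4 is therefore estimated to give about 1300 nM in this assay, with a likely range from 600 nM to 3000 nM.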

Compound 4, half-maximal inhibitory concentration: 3460 nM
Beside the measured number, compound 4's estimate is 2.7-fold (0.43 log units) below it; measured number above the stated range.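

In this assay the same change to methyl again raised the number, with a 7.7-fold higher number from compound 3 to compound 4 (0.89 log units; beyond the scatter), so the inhibition weakened on this second core as well. Set side by side, the two steps cannot be told apart, and the change carried over in direction and, as far as these data can resolve, in size: the same change on two cores in this assay, a 3.0-fold higher number (0.48 log units; beyond the scatter) from compound 2 to compound 1 and a 7.7-fold higher number (0.89 log units; beyond the scatter) from compound 3 to compound 4, 2.6-fold (0.41 log units) apart, within the scatter of two such steps. This rests on one pair for each of two cores, so it does not show that the step would hold on any further core, and it gives no reason for the weakening.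

The compounds shown carry only hydrogen or methyl at this place on the ring, so the effect of an ethyl group or a methoxy group there remains open. They also leave open whether the weakening is particular to the methyl group or would appear with other groups at that place.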